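The source may hold more compounds than are shown below. What is called first, only, known or untested is meant among the compounds shown, and "the series" means these compounds.

Measured in an ADME assay on L1210/0 cells (Mus musculus) for cytotoxicity, with a stated time of 48 h; a lower number here means a stronger inhibitor, a higher number a weaker inhibitor:
- compound 1 `O=c1[nH]c(=O)n([C@H]2C[C@H](O)[C@@H](CO)O2)cc1/C=N/O`: 15500 nM
- compound 2 `O=C(CI)NCc1cn([C@H]2C[C@H](O)[C@@H](CO)O2)c(=O)[nH]c1=O`: 107000 nM

Compound 2, at 107000 nM, has the higher of the two numbers in this assay, so it is the weaker inhibitor of the pair. Within the data shown here, the only measured step is a 6.9-fold higher number from compound 1 to compound 2 (0.84 log units; beyond the scatter). That step is a modest one, and it swaps one group for another on an aromatic carbon.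

Compound 3 `COCC#Cc1cn([C@H]2C[C@H](O)[C@@H](CO)O2)c(=O)[nH]c1=O` has not been measured yet. It differs from compound 2 at that same place on the shared core: 3-methoxyprop-1-yn-1-yl in place of (((iodomethyl)carbonyl)amino)methyl on an aromatic carbon. A 3-methoxyprop-1-yn-1-yl group replaces the (((iodomethyl)carbonyl)amino)methyl group.

The new group matches neither earlier group, so a single step gives a rough idea of size but no rule. Among the measured compounds shown here, a modest step is therefore expected, probably toward a lower number, as compound 2 at 107000 nM is the higher of only two values. The expected change is a 2.7-fold lower number from compound 2 to compound 3 (0.43 log units; beyond the scatter). For compound 3 the estimated value is 40000 nM, with an expected range from 8000 nM to 200000 nM.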

Compound 3, half-maximal inhibitory concentration: > 200000 nM
Compound 3 ended at the assay's limit (the forecaster's own chance of this, stated with the estimate: 25%); at least 5.0-fold (0.69 log units) between middle value and limit.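

The reading for compound 3 is a limit of the assay and not a number: the limit of > 200000 nM in this assay, at which 1 of the 3 values shown sits. Against compound 2 the result is only a floor, an at least 1.8-fold higher number from compound 2 to compound 3 (0.27 log units; that floor lies within the scatter), so compound 3 cannot be placed clearly apart from compound 2. Against compound 1 the gap is large, an at least 12-fold higher number from compound 1 to compound 3 (1.11 log units; beyond the scatter), and this is the new information: 3-methoxyprop-1-yn-1-yl has no iodine, no double bond outside the aromatic ring and no hydrogen-bond donors, yet it does not bring the number back toward that of compound 1, so the weak reading of compound 2 does not depend on the (((iodomethyl)carbonyl)amino)methyl group alone.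

From the compounds shown here alone, how far compound 3 lies past the limit stays open, and with it whether compound 3 truly differs from compound 2 in this assay. Also open, going by these compounds, is how an amine, a carboxylic acid or a shorter alkyne without the methoxy group would read on this aromatic carbon, and whether any of them could give a lower number than compound 1 at 15500 nM.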